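Swapping acetyl for dimethylamino on a pyrazole series

This account rests on a few compounds, and the source may have more. Where it says the series, first, only, none or still open, it means among the compounds named here.

Measured compounds:
compound 1, `COc1cc(C)cc(-c2c(-c3ccnc(-c4ccc(C(C)=O)cc4)c3)cnn2CC#N)c1`, 4220 nM
compound 2, `Cc1cc(O)cc(-c2nn(CC#N)cc2-c2ccnc(-c3ccc(N(C)C)cc3)c2)c1`, 2850 nM

In a functional assay on SK-OV-3 cells (Homo sapiens) for inhibition, read by sulforhodamine B assay, with a stated time of 48 h (on this read-out lower numbers stand for stronger inhibition of growth and higher numbers for weaker inhibition of growth), compound 1 gives 4220 nM, the highest of the two numbers recorded. Its nearest neighbour is compound 2, whose value in this assay lies within the usual scatter, so the two cannot be ordered against each other.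

Compound 3, `COc1cc(C)cc(-c2c(-c3ccnc(-c4ccc(N(C)C)cc4)c3)cnn2CC#N)c1`, has not been measured. It differs from compound 1 in one place: dimethylamino in place of acetyl on an aromatic carbon. Among the measured compounds shown here, compound 2 already carries a dimethylamino group at that same position, but it also differs from compound 1 elsewhere, so no clean step for this change exists among the measured compounds.

Given that compound 1 and compound 2 sit within the scatter of each other, no step beyond the scatter is expected for a 1.3-fold lower number from compound 1 to compound 3 (0.11 log units; within the scatter). Compound 3 is therefore estimated at 3300 nM in this assay, with a plausible range from 1400 nM to 8000 nM.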

Compound 3, concentration for 50% growth inhibition: 504 nM
Compound 3: the middle estimate sits 6.5-fold (0.82 log units) above what was measured, and the stated range ends above it.
By their numbers in this assay, from the lowest: compound 3; then compounds 2 and 1 (each within the scatter of the next).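

In this assay, dimethylamino in place of acetyl on this aromatic carbon brings an 8.4-fold lower number from compound 1 to compound 3 (0.92 log units; beyond the scatter). Among the compounds shown here, this is the first clean view of this position, since compound 1 and compound 2 differ in more than one place, and it shows that the group held here can change the growth-inhibition read-out beyond the scatter, even though the two groups match in heavy-atom count and hydrogen-bond acceptors. Nothing shown here accounts for the size of this step.

From the compounds shown here alone, it remains open whether dimethylamino is special or whether another group at this place, such as an unsubstituted amine, methoxy or a morpholine ring, would give a similar number. Also open, going by these compounds, is whether the same change would have a similar effect in compound 2, which differs from compound 3 elsewhere.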